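A few compounds are considered here, and "the series" means these few. Any claim that something is new, unique, unknown or untested is made for them only; others in the source may bear on it.

Measured so far:
compound 1 `COc1cc(C)c(S(=O)(=O)N(C)CCOCC(=O)N2CCC(C(C)(C)CN(C)C)CC2)c(C)c1`, 1.6 h
compound 2 `CCN1CCC(N2CCN(C(=O)COCCN(C)S(=O)(=O)c3c(C)cc(OC)cc3C)CC2)CC1`, 1.6 h

In an in vivo ADME assay on the whole organism (strain Sprague-Dawley) for metabolic stability, with Rattus norvegicus as the target (a lower number here means that the compound disappears faster, a higher number that the compound lasts longer), compound 1 gives 1.6 h, and compound 2 gives 1.6 h. Compound 1 thus stands level with compound 2 at the digits shown; the two values lie within the scatter of each other, and no order between them can be read from the numbers.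

Compound 3 `COc1cc(C)c(S(=O)(=O)N(C)CCOCC(=O)N2CCC(C3CCN(C)CC3)CC2)c(C)c1` remains to be measured in this assay. Its change relative to compound 1 is 1-methylpiperidin-4-yl in place of 1-((dimethylamino)methyl)-1-methylethyl on a saturated ring carbon. Within the data shown here, no comparison between measured compounds covers a change of this kind, so the numbers on hand give no direction for it. The group that leaves and the group that enters are of like size as counted, each with a single acceptor and no donor. The step of a 1.1-fold lower number from compound 1 to compound 3 (0.03 log units; within the scatter) is expected to stay within the scatter, with no movement beyond it in either direction. For compound 3 the estimate in this assay is 1.5 h, with a range from 0.8 h to 3.2 h.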

Compound 3, half-life: 1.3 h
The estimate for compound 3 lay 1.2-fold (0.06 log units) above the measured number, within the range that was stated.
By their numbers in this assay, from the lowest: compounds 3, 1 and 2 (each within the scatter of the next).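

In this assay the exchange of 1-((dimethylamino)methyl)-1-methylethyl for 1-methylpiperidin-4-yl on a saturated ring carbon gives a 1.2-fold lower number from compound 1 to compound 3 (0.09 log units; within the scatter) and so stays inside the scatter. Among these compounds, this is the first single-place comparison, and it shows that, for this one pair, closing the open chain into a six-membered non-aromatic ring with its nitrogen produces no readable shift in half-life at this position. No measurement on hand bears on what lies behind this result.

Both groups at this position carry a nitrogen, so the outcome with a nitrogen-free group such as cyclohexyl, or with a carboxylic acid, remains an open question in this assay. Going by these compounds, whether any group on this ring carbon can move the half-life beyond the scatter also stays open.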